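Notes on compound 2, compound 3 and one methoxy change

A few compounds are considered here, and "the series" means these few. Any claim that something is new, unique, unknown or untested is made for them only; others in the source may bear on it.

Two compounds of this series have measured values. Compound 1 `COc1ccc(-c2cc(/C=C/C(=O)c3ccc(N)cc3)[nH]n2)cc1` and compound 2 `COc1cc(-c2cc(/C=C/C(=O)c3ccc(N)cc3)[nH]n2)cc(OC)c1OC` share the same core and differ only in how many methoxy groups sit on one six-membered aromatic ring of carbon only. In a functional assay on NCI/ADR-RES cells (Homo sapiens) for cytotoxicity, read by sulforhodamine B assay, with a stated time of 48 h, tested at 10 uM (a higher number here means a weaker effect of the compound at the concentration tested, a lower number a stronger effect), compound 1 gives 9%. In this assay compound 2 gives 15%, the higher of the two numbers shown, yet the gap to compound 1 lies within the scatter, so neither compound stands apart from the other. Compound 3 `COc1ccc(-c2cc(/C=C/C(=O)c3ccc(N)cc3)[nH]n2)cc1OC` has not been measured. Relative to compound 2 it carries hydrogen in place of methoxy on an aromatic carbon. Among the measured compounds shown here, no step between measured compounds that differ in one place has been recorded, so the size of such a change in this assay is not known from this series; with both measured values low and close together, a step no larger than the scatter is expected, with no clear direction. Compound 3 is expected to give 12% in this assay, between 2% and 25%. The estimated step from compound 2 to compound 3 is a number 3 percentage points lower from compound 2 to compound 3 (within the scatter), expected to sit within the scatter.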

Compound 3, a percentage reported as activity, at one concentration (the size of the read-out at that concentration, not a potency): 37%
Compound 3: the middle estimate sits 25 percentage points below what was measured, outside the stated range (above it).
By their numbers in this assay, from the lowest: compounds 1 and 2 (each within the scatter of the next); then compound 3.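

In this assay, among the compounds shown here, the methoxy on this aromatic carbon, ortho to a methoxy group and meta to a large group, proves not to be silent: hydrogen in its place gives a number 22 percentage points higher from compound 2 to compound 3 (beyond the scatter) and so a weaker effect at the concentration tested, the first step beyond the scatter. Methoxy in place of hydrogen on an aromatic carbon, read from the other side of compound 3, gives a number 28 percentage points higher from compound 1 to compound 3 (beyond the scatter) and points the same way, so compound 3 stands apart from both of its one-place neighbours and the read-out does not follow the count of methoxy groups across these three compounds. Nothing at hand accounts for this pattern. The compounds shown leave open whether the weaker effect belongs to the loss of the methoxy at this carbon itself or to the particular arrangement of methoxy groups left on the ring. They also leave open what a hydroxyl group, a chlorine atom or an ethoxy group would give at this same aromatic carbon, and so whether methoxy is specifically needed there.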